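Acyclic amine in place of the piperazine on compound 3

The source may hold more compounds than are shown below. What is called first, only, known or untested is meant among the compounds shown, and "the series" means these compounds.

Measured compounds:
compound 1 `CS(=O)(=O)c1ccc(Nc2ncnc3sc(Nc4c(Cl)cccc4Cl)nc23)cc1`, in a functional assay on HEK293 cells for antagonist activity at transient receptor potential cation channel subfamily V member 1 (Homo sapiens), read by calcium flux (a higher number here means a weaker inhibitor, a lower number a stronger inhibitor), compound 1 gives 5 nM
compound 2 `FC(F)(F)c1ccc(Nc2nc(N3CCCC3)nc3sc(Nc4c(Cl)cccc4Cl)nc23)cc1`, in this assay compound 2 gives 12 nM
compound 3 `CC(C)N1CCN(c2nc(Nc3ccc(C(F)(F)F)cc3)c3nc(Nc4c(Cl)cccc4Cl)sc3n2)CC1`, in this assay compound 3 gives 184 nM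

Compound 3 stands highest of the three numbers in this assay; the nearest is compound 2, whose number is lower beyond the scatter, and the furthest is compound 1, lower still. Going by the values given here, only one measured step touches the position now in question: a 15-fold higher number from compound 2 to compound 3 (1.19 log units; beyond the scatter), a large upward move when the pyrrolidin-1-yl group was exchanged for the 4-isopropylpiperazin-1-yl group. Compound 1, which carries no amine substituent at that carbon, sits lowest of all; together the three numbers suggest that a larger group at this carbon goes with a higher number, though with one step only this is no more than a hint.

Compound 4 `CC(C)CNc1nc(Nc2ccc(C(F)(F)F)cc2)c2nc(Nc3c(Cl)cccc3Cl)sc2n1` differs from compound 3 by isobutylamino in place of 4-isopropylpiperazin-1-yl on an aromatic carbon. The entering group has no ring and is closer in size to the pyrrolidin-1-yl group of compound 2 than to the group it replaces. A downward step is therefore expected, beyond the scatter, but not a full return to the number of compound 2; the expected step is a 5.3-fold lower number from compound 3 to compound 4 (0.72 log units; beyond the scatter). Compound 4 is estimated at 35 nM, with a range from 9 nM to 140 nM.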

Compound 4, half-maximal inhibitory concentration: 2 nM
Estimate against measurement, compound 4: 18-fold (1.24 log units) above, and the stated range ends above it.
By their numbers in this assay, from the lowest: compound 4; then compound 1; then compound 2; then compound 3.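

In this assay, isobutylamino at this carbon gives a 92-fold lower number from compound 3 to compound 4 (1.96 log units; beyond the scatter), and the comparison with the smaller ring amine gives a 6.0-fold lower number from compound 2 to compound 4 (0.78 log units; beyond the scatter). Among the three compounds that carry the (4-(trifluoromethyl)phenyl)amino group, a ring at this carbon is therefore not needed for a low number, and the open-chain amine stands below both ring amines, each step lying beyond the scatter. The change from 4-isopropylpiperazin-1-yl to isobutylamino removes a ring, reduces the heavy atoms and adds a hydrogen-bond donor all at once, and no measurement bears on why the number falls so far.

As far as these compounds go, these compounds do not separate the three changes, so it remains open whether the gain follows the amine hydrogen, the open chain or the smaller group. A dimethylamino group would keep an open chain without the amine hydrogen, while a cyclopentylamino group would keep the amine hydrogen on a ring, and either would help to tell these apart.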